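From ethoxy to hydroxy at the edge of the assay

A few compounds are considered here, and "the series" means these few. Any claim that something is new, unique, unknown or untested is made for them only; others in the source may bear on it.

Measured in a functional assay on PC-3 cells (Homo sapiens) for cytotoxicity, read by MTT assay, with a stated time of 24 h; on this read-out higher numbers stand for weaker inhibition and lower numbers for stronger inhibition:
- Compound 1 `C=C1C(=O)[C@@]23C[C@@H]1CC[C@@H]2[C@@]1(C)CCCC(C)(C)[C@@H]1COC3=O`: 11500 nM
- Compound 2 `C=C1CC[C@H](C)[C@@](C)(CCC2=CC(OCC)OC2=O)C/C=C\C=C/1C(=O)O`: > 40000 nM (a limit)

Not every result in a cell test comes out as a number, and compound 2 shows this. Compound 2 stands at > 40000 nM in this assay, and this is a limit of the assay, not a measured number. Compound 1, by contrast, gives a true number, 11500 nM.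

Compound 3 `C=C1CC[C@H](C)[C@@](C)(CCC2=CC(O)OC2=O)C/C=C\C=C/1C(=O)O` is compound 2 with one small edit: hydrogen in place of ethyl on an oxygen on a saturated carbon. In words, hydrogen takes the place of ethyl on an oxygen on a saturated carbon, which turns ethoxy into hydroxy. Within the data shown here, no measured pair of compounds shows what this edit does, so the starting point is only the limit of compound 2, > 40000 nM.

No step beyond the scatter is expected in this assay, in either direction, and another limit is quite possible. The estimate amounts to a number no higher from compound 2 to compound 3 (the limit leaves the size open). For compound 3 the expected value is 40000 nM, with an estimated range from 15000 nM to 80000 nM.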

Compound 3, half-maximal inhibitory concentration: > 40000 nM
Compound 3 gave a limit, no number; the forecaster's own chance of this, stated with the estimate: 65%; the middle value lies on the limit itself.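

In this assay compound 3 gives > 40000 nM as a limit of the assay, not a number. Among these compounds, compound 2 also stands at a limit, so no step from ethoxy to hydroxy can be read between compound 2 and compound 3. The compounds shown leave open what this edit does to activity on these cells.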